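The source may report more compounds than this note shows. Statements on the series, on what has been measured and on what is new or still open speak of the compounds shown alone.

Measured compounds:
Compound 1 `O=C(CSc1nnnn1-c1ccccc1)N/N=c1/scc(-c2ccc(F)cc2)n1-c1ccccc1`: in a functional assay on C6 cells (Rattus norvegicus) for cytotoxicity, read by MTT assay, with a stated time of 24 h (a lower number here means a stronger inhibitor, a higher number a weaker inhibitor), compound 1 gives 24.3 ug/mL.
Compound 2 `Cn1cnnc1SCC(=O)N/N=c1/scc(-c2ccc(F)cc2)n1-c1ccccc1`: in this assay compound 2 gives "not determined" (no result reported).
Compound 3 `COc1ccc(-c2cs/c(=N/NC(=O)CSc3ncccn3)n2-c2ccccc2)cc1`: in this assay compound 3 gives 102 ug/mL.

Compound 3 stands with the highest of the two numbers in this assay; the nearest, compound 1, sits at a lower number, and that gap lies beyond the scatter. For the measured compounds named here, compound 1 and compound 3 differ in more than one place, so no single step between them is defined; their two values show only that compound 1, which carries the 4-fluorophenyl group, returns the lower number.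

Compound 4 `O=C(CSc1ncccn1)N/N=c1/scc(-c2ccc(F)cc2)n1-c1ccccc1` is not yet measured in this assay. It differs from compound 3 by fluoro in place of methoxy on an aromatic carbon; the same difference, cut one bond further out, reads 4-methoxyphenyl to 4-fluorophenyl, the aryl group found in compound 1. Going by the values given here, no step between measured compounds bears on this change alone. Compound 1, with the same 4-fluorophenyl group but differing elsewhere too, gives 24.3 ug/mL. On that basis the step of a 1.9-fold lower number from compound 3 to compound 4 (0.27 log units; within the scatter) is expected to run toward a lower number, of modest size and possibly no larger than the scatter. Compound 4 is estimated at 55 ug/mL in this assay, within a range from 20 ug/mL to 150 ug/mL.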

Compound 4, half-maximal inhibitory concentration: 110 ug/mL
For compound 4 the middle estimate is 2.0-fold (0.30 log units) below the measured one; low and high end bracket the measured number.
By their numbers in this assay, from the lowest: compound 1; then compounds 3 and 4 (each within the scatter of the next).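

In this assay, fluoro in place of methoxy on an aromatic carbon, para to a large group, is a step of a 1.1-fold higher number from compound 3 to compound 4 (0.03 log units; within the scatter), so the two groups cannot be told apart at this position in this pair. For the compounds shown here, the lower number of compound 1 therefore does not go with the 4-fluorophenyl group alone: with that group held constant, pyrimidin-2-yl in place of 1-phenyl-1H-tetrazol-5-yl on the sulfur is a step of a 4.5-fold higher number from compound 1 to compound 4 (0.66 log units; beyond the scatter), and among the compounds with numbers this is the only single change that lies beyond the scatter. No data at hand bear on the reason for either step.

Still open, on these data alone, is whether the step on the sulfur holds when 4-methoxyphenyl replaces 4-fluorophenyl, and whether an amine or a carboxylic acid in place of fluoro would shift the number in this assay where methoxy and fluoro do not. Also open, as far as these compounds go, is how a longer chain or a simple phenyl in place of the group on the sulfur would compare with pyrimidin-2-yl and 1-phenyl-1H-tetrazol-5-yl.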